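The compounds below may be only part of what the source reports. "The series", "measured", "known", "first", "only" and "open" are said of these compounds alone.

Measured compounds:
compound 1 `COc1cc2c(Oc3ccc(NC(=O)NN4C(=O)CSC4c4c(F)cccc4F)c4ccccc34)ccnc2cc1OCCCN1CCCC1`, 2360 nM
compound 2 `COc1cc2c(Oc3c(F)cc(NC(=O)NN4C(=O)CCSC4c4c(F)cccc4F)cc3F)ccnc2cc1OCCCN1CCCC1`, 400 nM
compound 3 `COc1cc2c(Oc3c(F)cc(NC(=O)NN4C(=O)CSC4c4c(F)cccc4F)cc3F)ccnc2cc1OCCCN1CCC(C)CC1`, 970 nM

These three compounds share a common core and were measured in a functional assay on A549 cells (Homo sapiens) for antiproliferative activity, read by MTT assay, with a stated time of 72 h; on this read-out higher numbers stand for weaker inhibition and lower numbers for stronger inhibition. Among them, compound 3 sits at the second highest number: its nearest neighbour is compound 2, which gives 400 nM, a lower number lying beyond the scatter, while the furthest is compound 1, which gives 2360 nM, a higher number also beyond the scatter. No two of these compounds differ in a single place, so the values are shown side by side without a counted step between them.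

Compound 4 `CCN1CCN(CCCCOc2cc3nccc(Oc4c(F)cc(NC(=O)NN5C(=O)CSC5c5c(F)cccc5F)cc4F)c3cc2OC)CC1` is not yet measured in this assay. Relative to compound 3 the change is (4-ethylpiperazin-1-yl)methyl in place of 4-methylpiperidin-1-yl on a saturated chain carbon, three bonds along the chain from an oxygen on an aromatic ring. Among the measured compounds shown here, since no step between measured compounds is known for a change of this kind, the expectation rests on the general spread seen across compounds 1 to 3 rather than on a measured precedent, and the change is expected to make a step within the scatter, in either direction: the step from compound 3 to compound 4 is estimated as a 1.2-fold lower number from compound 3 to compound 4 (0.08 log units; within the scatter). Compound 4 is therefore expected to give about 800 nM in this assay, within a range from 300 nM to 2500 nM.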

Compound 4, half-maximal inhibitory concentration: 1390 nM
Compound 4: middle estimate off by 1.7-fold (0.24 log units), on the low side, and the stated range covers the measured number.
By their numbers in this assay, from the lowest: compound 2; then compounds 3, 4 and 1 (each within the scatter of the next, the first and the last beyond it).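

In this assay, among the compounds shown here, replacing 4-methylpiperidin-1-yl with (4-ethylpiperazin-1-yl)methyl, on a saturated chain carbon, three bonds along the chain from an oxygen on an aromatic ring, gives the first counted step in this set: a 1.4-fold higher number from compound 3 to compound 4 (0.16 log units; within the scatter). Read one bond further out, this is a change from 3-(4-methylpiperidin-1-yl)propyl to 4-(4-ethylpiperazin-1-yl)butyl, so a longer chain and a different ring with a different substituent arrive together, yet this read-out does not tell the two compounds apart. Nothing among the data shown bears on why the step is this small.

The compounds shown leave open how much the chain and the ring would each contribute alone, which 3-(4-ethylpiperazin-1-yl)propyl or 4-(4-methylpiperidin-1-yl)butyl on the same core would help to separate. Going by these compounds, it also remains open whether a morpholine or a carboxylic acid in place of the 4-methylpiperidin-1-yl group would stay within the scatter of compound 3 or move the number beyond it.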